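This account rests on a few compounds, and the source may have more. Where it says the series, first, only, none or still open, it means among the compounds named here.

Compound 1 `CC(C)N1CCN(CCN2CCC(c3cn(-c4ccccc4)c4cc(Cl)ccc34)CC2)C1=O`: 39 nM
Compound 2 `CNC(=O)N(C)CCN1CCC(c2cn(-c3ccc(F)cc3)c3cc(Cl)ccc23)CC1`: 16 nM

In an assay on cell membranes for displacement of a labelled ligand from Adrenergic receptor alpha-1 (Rattus norvegicus) (a lower number here means a stronger inhibitor, a higher number a weaker inhibitor), compound 1 gives 39 nM, and compound 2 gives 16 nM. Of the two numbers, compound 2 has the lower one, and its gap to compound 1 lies beyond the scatter of the method.

Compound 3 `CN(C)C(=O)NCCN1CCC(c2cn(-c3ccc(F)cc3)c3cc(Cl)ccc23)CC1` has not yet been measured in this assay. It differs from compound 2 in a single place: (dimethylcarbamoyl)amino in place of methyl(methylcarbamoyl)amino on a saturated chain carbon, two bonds along the chain from an amine nitrogen in a ring. Within the data shown here, no pair of measured compounds shows this kind of change, so nothing in the measured data sets the size of the step. The two structures hold the same atoms joined differently. Only a modest step in this assay is expected, toward a somewhat higher number if anything beyond the scatter. Compound 3 is therefore estimated at 25 nM, within a range of 8 nM to 80 nM. The expected step reads a 1.6-fold higher number from compound 2 to compound 3 (0.19 log units; within the scatter).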

Compound 3, half-maximal inhibitory concentration: 29 nM
For compound 3 the middle estimate is 1.2-fold (0.06 log units) below the measured one, and the stated range covers the measured number.
By their numbers in this assay, from the lowest: compounds 2, 3 and 1 (each within the scatter of the next, the first and the last beyond it).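

In this assay, placing (dimethylcarbamoyl)amino in place of methyl(methylcarbamoyl)amino on a saturated chain carbon, two bonds along the chain from an amine nitrogen in a ring, reads as a 1.8-fold higher number from compound 2 to compound 3 (0.26 log units; within the scatter), the first step measured at this place. The two groups hold the same atoms and the same counts of hydrogen-bond donors and acceptors, and this rearrangement does not separate the two compounds in this assay. Nothing measured here bears on the origin of this step.

Going by these compounds, it remains open how this place responds to a group of a different kind, such as a plain amine, a carboxylic acid or a longer chain ending in the same (dimethylcarbamoyl)amino group. Compound 1 differs from the other two in more than one place, so the effect of its side chain cannot be read separately.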